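Amide-side heteroaryl exchange and macrophage cytotoxicity read-out

A few compounds are considered here, and "the series" means these few. Any claim that something is new, unique, unknown or untested is made for them only; others in the source may bear on it.

Measured so far:
compound 1, `O=C(Cn1c(=O)oc2cc([N+](=O)[O-])ccc21)Nc1ccccn1`, gives 47.3% in an ADME assay on RAW264.7 cells (Mus musculus) for cytotoxicity, read by MTT assay, with a stated time of 72 h, tested at 100 uM; on this read-out higher numbers stand for a stronger effect at the one concentration tested and lower numbers for a weaker effect
compound 2, `O=C(Cn1c(=O)oc2cc([N+](=O)[O-])ccc21)NCc1ccco1`, gives 60.1% in this assay
compound 3, `O=C(Cn1c(=O)oc2cc([N+](=O)[O-])ccc21)NCc1cccs1`, gives 41% in this assay

Compound 3 has the lowest of the three numbers; compound 1 is the nearest, within the scatter, and compound 2 the furthest, beyond the scatter. Compound 4, `O=C(Cn1c(=O)oc2cc([N+](=O)[O-])ccc21)NCc1ccccn1`, has not yet been measured. It differs from compound 3 in one place: pyridin-2-yl in place of thiophen-2-yl on a saturated chain carbon bound to an amide-type nitrogen.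

Among the compounds with values here, two measured steps bear on this. The exchange of one five-membered heteroaryl for another on the same saturated chain carbon gave a number 19.1 percentage points lower from compound 2 to compound 3 (beyond the scatter). The pyridin-2-yl group on the amide nitrogen itself, compared with the (thiophen-2-yl)methyl group, gave a number 6.3 percentage points lower from compound 1 to compound 3 (within the scatter). Ring exchanges on the amide side thus move the read-out at most modestly, and in compound 4 the pyridin-2-yl ring is one carbon further out than in compound 1. For compound 4 in this assay a step of about a number 7 percentage points higher from compound 3 to compound 4 (within the scatter) is expected, upward if anything but not clearly beyond the scatter, so compound 4 is estimated at 48% with a range of 35% to 62%.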

Compound 4, a percentage reported as inhibition, at one concentration (the size of the read-out at that concentration, not a potency): 33.4%
The estimate for compound 4 lay 14.6 percentage points above the measured number, and the stated range ends above it.
By their numbers in this assay, from the lowest: compounds 4, 3 and 1 (each within the scatter of the next, the first and the last beyond it); then compound 2.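

In this assay, pyridin-2-yl in place of thiophen-2-yl on a saturated chain carbon bound to an amide-type nitrogen gives a number 7.6 percentage points lower from compound 3 to compound 4 (within the scatter), so the change from a five-membered to a six-membered aromatic ring does not by itself separate these two compounds. Furan-2-yl stands apart at this place, with a number 26.7 percentage points lower from compound 2 to compound 4 (beyond the scatter), and compound 2 is also separated from compound 3 by a step beyond the scatter. Within the data shown here, with the pyridin-2-yl ring held constant, (pyridin-2-yl)methyl in place of pyridin-2-yl on the amide-type nitrogen gives a number 13.9 percentage points lower from compound 1 to compound 4 (beyond the scatter), the first reading of this link without a change of ring.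

Open, from the compounds shown here alone, is how a longer chain before the ring, or a phenyl ring at this place, would read. No measurement offered here accounts for these steps.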